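Shortening the side chain of compound 2

The source may hold more compounds than are shown below. What is called first, only, known or untested is meant among the compounds shown, and "the series" means these compounds.

Compound 1 `O=C(NCCCCc1ccccc1)n1c2c(oc1=O)CNCC2`: > 2 h
Compound 2 `CC(C)CN1CCC(c2ccc3c(c2)oc(=O)n3C(=O)NCCCCc2ccccc2)CC1`: 1 h

For the measured compounds named here, in an ADME assay on a cell-free system (plasma, Mus musculus) for metabolic stability, read by LC-MS, tested at 2 uM (a higher number here means that the compound lasts longer, a lower number that the compound disappears faster), compound 2 gives 1 h, the only actual number so far. Compound 1 gives > 2 h, which is a limit of the assay and not a number.

Compound 3 `CCN1CCC(c2ccc3c(c2)oc(=O)n3C(=O)NCCCCc2ccccc2)CC1` differs from compound 2 in one place: methyl in place of isopropyl on a saturated chain carbon bound to an amine nitrogen in a ring. This is methyl in place of isopropyl on a saturated chain carbon bound to an amine nitrogen in a ring, so isobutyl becomes ethyl. Going by the values given here, no measured pair shows the effect of such a change, so no step beyond the usual scatter is expected in this assay. The estimated step of a 1.2-fold higher number from compound 2 to compound 3 (0.08 log units; within the scatter) stays within that scatter. For compound 3 the expected half-life is 1.2 h, with an expected range from 0.5 h to 2.5 h.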

Compound 3, half-life: 0.833 h
Beside the measured number, compound 3's estimate is 1.4-fold (0.16 log units) above it; the measured number falls inside the stated range.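

In this assay, for the compounds shown here, this is the first pair that differs in one place, and it gives a 1.2-fold lower number from compound 2 to compound 3 (0.08 log units; within the scatter). Compounds with 1-isobutylpiperidin-4-yl and 1-ethylpiperidin-4-yl therefore cannot be told apart here, so removing these carbons from the chain has no visible effect on half-life. Nothing shown bears on why the two compounds behave alike.

On these data alone, whether a longer chain, a benzyl group or a carboxylic acid in this place would give a half-life clearly different from these two remains open.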